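The compounds below may be only part of what the source reports. "The series", "measured", "known", "first", "only" and "open" are said of these compounds alone.

The study concerns three measured carbamates sharing one core and a fourth not yet measured. Compound 1 `C=CCOC(=O)Nc1ccc([Se]C#N)cc1` and compound 2 `CCCOC(=O)Nc1ccc([Se]C#N)cc1` were assayed in a functional assay on CCRF-CEM cells (Homo sapiens) for cytotoxicity, read by MTT assay, with a stated time of 72 h; a higher number here means a weaker inhibitor of growth, a lower number a stronger inhibitor of growth; compound 1 gives 9200 nM, and compound 2 gives 9300 nM. Compound 3 `N#C[Se]c1ccc(NC(=O)OCc2ccccc2)cc1` gives 23200 nM in this assay, the highest number of the three, standing a 2.5-fold higher number from compound 2 to compound 3 (0.40 log units; beyond the scatter) and a 2.5-fold higher number from compound 1 to compound 3 (0.40 log units; beyond the scatter). Compound 4 `CCOC(=O)Nc1ccc([Se]C#N)cc1` has not been measured; it differs from compound 3 in one place: methyl in place of phenyl on a saturated chain carbon bound to an oxygen next to a carbonyl group. Among the measured compounds shown here, the steps that bear on this change are those that introduced the phenyl, a 2.5-fold higher number from compound 2 to compound 3 (0.40 log units; beyond the scatter) and a 2.5-fold higher number from compound 1 to compound 3 (0.40 log units; beyond the scatter), each a modest rise beyond the scatter, while a 1.0-fold higher number from compound 1 to compound 2 (0.00 log units; within the scatter) shows that ethyl and vinyl are not told apart here. Replacing the phenyl with methyl is therefore expected to reverse that modest rise, giving a lower number in this assay for compound 4, with an expected step of a 2.4-fold lower number from compound 3 to compound 4 (0.39 log units; beyond the scatter). Compound 4 is thus estimated at 9500 nM, in a range from 5000 nM to 18000 nM.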

Compound 4, concentration for 50% growth inhibition: 9800 nM
Compound 4: middle estimate off by 1.0-fold (0.01 log units), on the low side; measured number inside the range.
By their numbers in this assay, from the lowest: compounds 1, 2 and 4 (each within the scatter of the next); then compound 3.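

In this assay, the direct exchange of phenyl for methyl on a saturated chain carbon bound to an oxygen next to a carbonyl group gives a modest step beyond the scatter (a 2.4-fold lower number from compound 3 to compound 4 (0.37 log units; beyond the scatter)). Methyl cannot be told apart from the other small groups at this position (a 1.1-fold higher number from compound 2 to compound 4 (0.02 log units; within the scatter); a 1.1-fold higher number from compound 1 to compound 4 (0.03 log units; within the scatter)), so among the four compounds methyl, ethyl and vinyl form one group, and compound 3, with its phenyl, is the only one that stands apart. Nothing measured here accounts for that difference.

The compounds shown leave open whether a longer chain, such as butyl, would stay with that group or move towards compound 3. They also leave open how a chain ending in an amine or a carboxylic acid would behave at this position.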